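Furan-3-yl in Place of 3,5-Difluorophenyl on a Thiazole Core

The source may hold more compounds than are shown below. What is called first, only, known or untested is meant among the compounds shown, and "the series" means these compounds.

Compound 1 `O=C(O)Cc1sc(COc2ccc(Cl)cc2)nc1-c1ccc(Cl)cc1`: 370 nM
Compound 2 `O=C(O)Cc1sc(C(c2ccccc2)c2ccccn2)nc1-c1ccc(Cl)cc1`: 1900 nM
Compound 3 `O=C(O)Cc1sc(C(c2ccc(F)cc2)c2ccc(F)cc2)nc1-c1cc(F)cc(F)c1`: 340 nM

Three compounds sharing one core were characterised in an in vitro functional assay on HEK285-7 cells for antagonist activity at prostaglandin D2 receptor 2 (Homo sapiens), read by BRET and beta-arrestin recruitment; on this read-out higher numbers stand for weaker inhibition and lower numbers for stronger inhibition. Compound 1 gives 370 nM, compound 2 gives 1900 nM, and compound 3 gives 340 nM. Compound 3 carries the lowest number of the three, yet its gap to compound 1 lies within the scatter, so these two cannot be told apart; only the gap to compound 2 is beyond the scatter. Compound 3 therefore stands with compound 1 at the stronger end of this small set, with compound 2 clearly weaker.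

Compound 4 `O=C(O)Cc1sc(C(c2ccc(F)cc2)c2ccc(F)cc2)nc1-c1ccoc1` is the next step. It differs from compound 3 in one place: furan-3-yl in place of 3,5-difluorophenyl on an aromatic carbon. Among the measured compounds shown here, no pair of measured compounds differs in exactly this way, so the data give no direct guide to the size of the step. The diarylmethyl group on the other side of the core is kept. Compound 4 is expected to lose some potency, the step of a 2.9-fold higher number from compound 3 to compound 4 (0.47 log units; beyond the scatter) being beyond the scatter but modest. Compound 4 is thus estimated at 1000 nM, with a range from 300 nM to 4000 nM.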

Compound 4, half-maximal inhibitory concentration: 130 nM
For compound 4 the middle estimate is 7.7-fold (0.89 log units) above the measured one; measured number outside the range, below it.
By their numbers in this assay, from the lowest: compound 4; then compounds 3 and 1 (each within the scatter of the next); then compound 2.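

In this assay, among the compounds shown here, furan-3-yl in place of 3,5-difluorophenyl gives a 2.6-fold lower number from compound 3 to compound 4 (0.42 log units; beyond the scatter), which is the first single-place change at this position in the set. The position, an aromatic carbon next to the ring nitrogen and next to the ring atom that bears a carboxymethyl group, therefore accepts a five-membered aromatic ring with 1 hetero atom in place of a six-membered aromatic ring of carbon only, with the diarylmethyl group kept and no loss on this read-out. The change alters several things at once (ring size, the two fluorine atoms, the oxygen as a hydrogen-bond acceptor), and nothing measured here bears on which of them accounts for the lower number.

The compounds shown leave open whether the oxygen itself matters, which a thienyl or an unsubstituted phenyl group at this position would help to separate from ring size and from the fluorine atoms. They also leave open whether the furan-3-yl step carries over when the diarylmethyl group gives way to the aryloxymethyl group of compound 1.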